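Adding a methyl to the hydroxyacetyl amide

A few compounds are considered here, and "the series" means these few. Any claim that something is new, unique, unknown or untested is made for them only; others in the source may bear on it.

compound 1 `C[C@H](O)C(=O)N1CCC(CCn2c(Sc3cc4c(cc3Br)CCO4)nc3c(N)ncnc32)CC1` gives 11000 nM
compound 2 `Nc1ncnc2c1nc(Sc1cc3occc3cc1Br)n2CCC1CCN(C=O)CC1` gives 1100 nM
compound 3 `Nc1ncnc2c1nc(Sc1cc3c(cc1Br)OCCO3)n2CCC1CCN(C(=O)CO)CC1` gives 10000 nM

All three numbers come from a functional assay on NCI/ADR-RES cells (Homo sapiens) for inhibition, read by luminescence, with a stated time of 72 h (a higher number here means a weaker inhibitor, a lower number a stronger inhibitor), in the same way. Compound 3 at 10000 nM is level with compound 1 within the scatter, while compound 2 has a lower number, beyond the scatter.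

Compound 4 `C[C@@H](O)C(=O)N1CCC(CCn2c(Sc3cc4c(cc3Br)OCCO4)nc3c(N)ncnc32)CC1` is not yet measured. It differs from compound 3 by methyl in place of hydrogen on a saturated chain carbon bound to a carbonyl carbon and an oxygen on a saturated carbon, and the change reads hydroxymethyl to 1-hydroxyethyl.

For the measured compounds named here, no step between measured compounds covers this change. Going by the values given here, compound 1 is the only measured compound bearing 1-hydroxyethyl and gives 11000 nM on its own core, so no shift beyond the scatter is expected in this assay in either direction. The expected size is a 1.1-fold lower number from compound 3 to compound 4 (0.05 log units; within the scatter) and it should stay within the scatter. Compound 4 is estimated at 9000 nM (expected range 3500 nM to 25000 nM).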

Compound 4, half-maximal inhibitory concentration: 9800 nM
For compound 4 the middle estimate is 1.1-fold (0.04 log units) below the measured one; the range from low to high includes it.
By their numbers in this assay, from the lowest: compound 2; then compounds 4, 3 and 1 (each within the scatter of the next).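

In this assay, methyl in place of hydrogen on a saturated chain carbon bound to a carbonyl carbon and an oxygen on a saturated carbon, which reads hydroxymethyl to 1-hydroxyethyl, gives a 1.0-fold lower number from compound 3 to compound 4 (0.01 log units; within the scatter). For the compounds shown here, this is the first reading of the change on a single core: 1-hydroxyethyl previously stood only on compound 1, whose core differs from that of compound 3, so the methyl could not be read apart from the core. On this core the added methyl brings no shift beyond the scatter, and nothing available bears on why.

From the compounds shown here alone, whether an amine in place of the hydroxyl, or a longer chain in place of the methyl, would move the number remains open. Compound 2 differs from compound 3 in more than one place, so its lower number cannot be assigned to either the amide or the core.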